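Adding a Polar Side Group to a Fast-Cleared Compound

The source may report more compounds than this note shows. Statements on the series, on what has been measured and on what is new or still open speak of the compounds shown alone.

Compound 1 (`CC#C[C@H]1CN(S(=O)(=O)c2ccc(N)nc2)CCN1c1ccccc1`) is the starting point. In an ADME assay (liver) for metabolic stability, with Liver microsome (Rattus norvegicus) as the target, using microsomes and NADPH, with a stated time of 30 min (on this read-out higher numbers stand for fast clearance and lower numbers for slow clearance), compound 1 gives > 399 mL.min-1.g-1, which is a limit of the assay and not a number. As far as these compounds go, it therefore marks the fast end of what the test reports, and the true figure remains unknown.

Compound 2 (`CC#C[C@H]1CN(S(=O)(=O)c2ccc(N)nc2)CCN1c1ncc(C(C)(O)C(F)(F)F)s1`) offers a second reference, because compound 2 gives 87 mL.min-1.g-1 as a measured number. It shows that a member of this family can fall within the reported range.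

Compound 3 (`CC#C[C@H]1CN(S(=O)(=O)c2ccc(N)nc2)CCN1c1ccc([C@@](O)(CO)C(F)(F)F)cc1`) keeps the core of compound 1 and changes one place: a group of 8 heavy atoms (3 carbon, 2 oxygen, 3 fluorine; no ring) in place of a hydrogen atom, on an aromatic carbon. The new group sits on an aromatic carbon, para to a large group.

Within the data shown here, no measured pair isolates this change, so the guide is indirect. Resting on compound 2 and its 87 mL.min-1.g-1, a large fall in clearance is expected, well beyond the usual scatter. The estimated change is an at least 6.6-fold lower number from compound 1 to compound 3 (0.82 log units; beyond the scatter), a figure made less certain by the limit at its starting point. In this assay compound 3 is expected to give 60 mL.min-1.g-1, with an estimated range from 20 mL.min-1.g-1 to 170 mL.min-1.g-1.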

Compound 3, intrinsic clearance in microsomes: 53 mL.min-1.g-1
The estimate for compound 3 lay 1.1-fold (0.05 log units) above the measured number; measured number inside the range.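

Among these compounds, compound 3 gives the first clean reading at this place, on an aromatic carbon of a six-membered aromatic ring of carbon only, para to a large group. In this assay, putting the group of 8 heavy atoms in place of a hydrogen atom gives an at least 7.5-fold lower number from compound 1 to compound 3 (0.87 log units; beyond the scatter), a change in one place that compound 2 could not show, since its ring differs from that of compound 1 as well as its side group. For compound 1 the starting value is a limit and not a number, so the step has a known minimum but no known full size: the limit of > 399 mL.min-1.g-1 in this assay, at which 1 of the 3 values shown sits.

One step cannot tell whether the whole group of 8 heavy atoms is needed for this change, or whether a single part of it would give the same drop, and it cannot tell what the defined stereocentre contributes. The compounds shown also leave open what a different group at this same place, such as an amine, a carboxylic acid or a longer carbon chain, would do to the clearance read-out.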